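A few compounds are considered here, and "the series" means these few. Any claim that something is new, unique, unknown or untested is made for them only; others in the source may bear on it.

Compound 1 `Nc1nc2cc(Cl)c(Cl)cc2n1Cc1cccc(Cl)c1` gives 37000 nM in a functional assay on CEM-SS cells (Homo sapiens) for cytotoxicity; a lower number here means a stronger inhibitor, a higher number a weaker inhibitor.
Compound 2 `Cc1cccc(Cn2c(N)nc3cc(Cl)c(Cl)cc32)c1` gives 48000 nM in this assay.
Compound 3 `Clc1cccc(Cn2c(Br)nc3cc(Cl)c(Cl)cc32)c1` reaches only a limit of > 100000 nM in this assay.

Compound 3 differs from compound 1 by bromo in place of amino on an aromatic carbon. That change made an at least 2.7-fold higher number from compound 1 to compound 3 (0.43 log units; beyond the scatter). The value of compound 3 is a limit, not a number, which is the limit of > 100000 nM in this assay, at which 1 of the 3 values shown sits. Compound 2 differs from compound 1 by methyl in place of chloro on an aromatic carbon, and that change made a 1.3-fold higher number from compound 1 to compound 2 (0.11 log units; within the scatter). Compound 4 `Cc1cccc(Cn2c(Br)nc3cc(Cl)c(Cl)cc32)c1` is not yet measured; it differs from compound 3 by methyl in place of chloro on an aromatic carbon, the same change as from compound 1 to compound 2, at the same place. Because a 1.3-fold higher number from compound 1 to compound 2 (0.11 log units; within the scatter) lies within the scatter, compound 4 is expected to show a step that the limit leaves unreadable from compound 3 to compound 4 in this assay. For compound 4 the estimate is 130000 nM, within 60000 nM and 300000 nM, most likely reported only as a limit.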

Compound 4, half-maximal inhibitory concentration: > 100000 nM
Compound 4 gave a limit, no number; the forecaster's own chance of this, stated with the estimate: 85%; the middle value does not contradict the limit.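

Bromo in place of amino makes an at least 2.0-fold higher number from compound 2 to compound 4 (0.31 log units; beyond the scatter) in this assay, and the same change raises the number on both cores: the same change on two cores in this assay, an at least 2.7-fold higher number (0.43 log units; beyond the scatter) from compound 1 to compound 3 and an at least 2.0-fold higher number (0.31 log units; beyond the scatter) from compound 2 to compound 4; the limit leaves it open whether they differ. Compound 3 and compound 4 both stand at a limit, so the step between them cannot be read: the limit of > 100000 nM in this assay, at which 2 of the 4 values shown sit. Going by these compounds, the direction of the change therefore carries from one core to the other, but its true size on either core remains unknown, as does any effect of methyl in place of chloro on the bromo compounds.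

The compounds shown leave open what other groups would do in place of amino, such as a methylamino group, a hydroxyl or a carboxylic acid. They also leave open what an ethyl group or a longer chain would do in place of the methyl.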